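A pyridin-2-yl exchange on the shared core

The source may report more compounds than this note shows. Statements on the series, on what has been measured and on what is new or still open speak of the compounds shown alone.

Compound 1 `Clc1ccc(-c2cc(-c3ccoc3)cc(-c3ccco3)n2)s1` gives 1280 nM
Compound 2 `Clc1ccc(-c2cc(-c3ccoc3)cc(-c3ccccc3Cl)n2)s1` gives 1100 nM

In a functional assay on HCT-15 cells (Homo sapiens) for cytotoxicity, read by ELISA, with a stated time of 4 days (a higher number here means a weaker inhibitor, a lower number a stronger inhibitor), compound 2 gives 1100 nM and stands within the scatter of compound 1 with 1280 nM as its value. Compound 3 `Clc1ccc(-c2cc(-c3ccoc3)cc(-c3ccccn3)n2)s1` carries pyridin-2-yl in place of 2-chlorophenyl on an aromatic carbon, and pyridin-2-yl in place of 2-chlorophenyl on an aromatic carbon sets out that exchange. Among the compounds with values here, the one measured step that bears on this, 2-chlorophenyl in place of furan-2-yl on an aromatic carbon, is a 1.2-fold lower number from compound 1 to compound 2 (0.07 log units; within the scatter) and lies within the scatter, so no step beyond the scatter is expected in this assay here. The expected step is a 1.1-fold higher number from compound 2 to compound 3 (0.04 log units; within the scatter) and remains only an estimate. For compound 3 the estimated value is 1200 nM with 500 nM as the lower end and 2900 nM as the upper end of the expected range.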

Compound 3, half-maximal inhibitory concentration: 1270 nM
Compound 3: middle estimate off by 1.1-fold (0.02 log units), on the low side; the range from low to high includes it.
By their numbers in this assay, from the lowest: compounds 2, 3 and 1 (each within the scatter of the next).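

In this assay the exchange of 2-chlorophenyl for pyridin-2-yl, which brings in a ring nitrogen and a hydrogen-bond acceptor, gives a 1.2-fold higher number from compound 2 to compound 3 (0.06 log units; within the scatter) and the exchange of furan-2-yl for pyridin-2-yl gives a 1.0-fold lower number from compound 1 to compound 3 (0.00 log units; within the scatter). All three aromatic rings at this position, next to the ring nitrogen, thus stand within the scatter of one another. No measurement is at hand to explain this. The compounds shown leave open whether an amine, a carboxylic acid or a longer chain here would give a step beyond the scatter. They also leave open what the furan-3-yl and 5-chlorothiophen-2-yl groups contribute.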